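The source may hold more compounds than are shown below. What is called first, only, known or untested is meant among the compounds shown, and "the series" means these compounds.

In an in vivo ADME assay on the whole organism (strain Sprague-Dawley) for pharmacokinetics, with Rattus norvegicus as the target (a higher number here means that more of the compound sits outside the plasma, a lower number that more of the compound stays in the plasma), two compounds sharing a core have been measured. Compound 1 (`COc1cc(C)c(S(=O)(=O)N(C)CCOCC(=O)N2CCC(C(C)(C)CN(C)C)CC2)c(C)c1`) gives 0.5 L/kg, and compound 2 (`COc1cc(C)c(S(=O)(=O)N(C)CCOCC(=O)N2CCN(CC3CCN(C)CC3)CC2)c(C)c1`) gives 3.5 L/kg, the higher of the two numbers, with a gap beyond the scatter. Compound 3 (`CCN1CCC(N2CCN(C(=O)COCCN(C)S(=O)(=O)c3c(C)cc(OC)cc3C)CC2)CC1`) has not yet been measured. It carries 1-ethylpiperidin-4-yl in place of the (1-methylpiperidin-4-yl)methyl of compound 2, on an amine nitrogen in a ring: 1-ethylpiperidin-4-yl in place of (1-methylpiperidin-4-yl)methyl on an amine nitrogen in a ring. The two have the same atoms, joined differently. For the measured compounds named here, no measured pair differs in one place only, so the data show no direct precedent for this change, and the expectation rests on compound 2 at 3.5 L/kg. The estimate is a small 1.2-fold lower number from compound 2 to compound 3 (0.07 log units; within the scatter), expected to stay within the scatter. Compound 3 is therefore expected at 3 L/kg, with an estimated range of 1.4 L/kg to 6 L/kg.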

Compound 3, volume of distribution: 3.8 L/kg
Estimate against measurement, compound 3: 1.3-fold (0.10 log units) below, and the stated range covers the measured number.
By their numbers in this assay, from the lowest: compound 1; then compounds 2 and 3 (each within the scatter of the next).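

For the compounds shown here, replacing (1-methylpiperidin-4-yl)methyl with 1-ethylpiperidin-4-yl on an amine nitrogen in a ring gives a 1.1-fold higher number from compound 2 to compound 3 (0.04 log units; within the scatter) in this assay and this is the first pair here that differs in one place only. At this position, two groups with the same atoms, joined differently, therefore read alike. Nothing available explains this result.

Both groups hold a six-membered non-aromatic ring, so the compounds shown leave open whether the number would hold with a morpholine or an open dimethylaminoethyl chain on the same nitrogen. Compound 1 differs from compound 2 and compound 3 in more than one place, so it cannot show which structural change accounts for its separate position in this series.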